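The compounds below may be only part of what the source reports. "The series", "measured", "known", "first", "only" and "open" are said of these compounds alone.

The three measured compounds share one core. Compound 1 `O=C(NCc1ccc(F)cc1)c1nc(Br)c2cccnc2c1NCCCNc1c(C(=O)NCc2ccc(F)cc2)nc(Br)c2cccnc12` joins two copies of that core through a chain. In a functional assay on HCT-116 cells (Homo sapiens) for cytotoxicity, read by MTT assay, with a stated time of 72 h (a higher number here means a weaker inhibitor, a lower number a stronger inhibitor), compound 1 gives only a limit, > 20000 nM, and no number. Compound 2 `O=C(NCc1ccc(F)cc1)c1nc(Br)c2cccnc2c1NCc1ccc(F)cc1` carries a single (4-fluorobenzyl)amino group on the core. In this assay compound 2 also gives only a limit, > 20000 nM. Compound 2 thus sits on (the limit of > 20000 nM in this assay, at which 2 of the 3 values shown sit), the same limit as compound 1. Within the data shown here, compound 3 `N[C@H]1CC[C@H](Nc2c(C(=O)NCc3ccc(F)cc3)nc(N3CCCCC3)c3cccnc23)CC1` differs from both in more than one place, and in this assay compound 3 gives 8500 nM, the one actual number so far.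

Compound 4 `CNCCCNc1c(C(=O)NCc2ccc(F)cc2)nc(Br)c2cccnc12` is not yet measured. It differs from compound 2 in a single place: 2-(methylamino)ethyl in place of 4-fluorophenyl on a saturated chain carbon bound to a nitrogen on an aromatic ring. Among the measured compounds shown here, no measured pair matches this exchange, so the expectation rests on the limit of compound 2 and the single number of compound 3. The step from compound 2 to compound 4 is expected to be an at least 1.3-fold lower number from compound 2 to compound 4 (0.12 log units; that floor lies within the scatter), a move toward a stronger inhibitor that may not clear the limit. Compound 4 is expected to give 15000 nM in this assay, between 5000 nM and 40000 nM.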

Compound 4, half-maximal inhibitory concentration: > 10000 nM
Compound 4 ended at the assay's limit; the forecaster's own chance of this, stated with the estimate: 45%; the middle value lies beyond the limit too.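

Compound 4 gives only a limit in this assay, > 10000 nM, and compound 2 also gives only a limit, so the step from compound 2 to compound 4 cannot be read. The compounds shown leave open whether (3-(methylamino)propyl)amino in place of (4-fluorobenzyl)amino changes the cytotoxicity at all, and in which direction.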